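Amine-to-hydroxy swap on the chain of compound 3

This account rests on a few compounds, and the source may have more. Where it says the series, first, only, none or still open, it means among the compounds named here.

Compound 3 `COc1cc(OC)c2c(=O)cc(-c3ccc(OCC(O)CN(C)C)cc3)oc2c1` holds the highest of the two numbers in a functional assay (Homo sapiens) for antiproliferative activity, read by resazurin assay, with a stated time of 48 h, tested at 10 uM (on this read-out lower numbers stand for a weaker effect and higher numbers for a stronger effect at the one concentration tested), giving 60%. Going by the values given here, compound 2 `COc1cc(OC)c2c(=O)cc(-c3ccc(OCC(O)CN4CCCC4)cc3)oc2c1` gives 37%, and the change a number 23 percentage points higher from compound 2 to compound 3 (beyond the scatter) is the only measured step. Compound 1 `COc1cc(OC)c2c(=O)cc(-c3ccc(OCCF)cc3)oc2c1`, which carries neither amine nor hydroxy on its chain, is reported as "not active" (no number reported).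

Compound 4 `COc1cc(OC)c2c(=O)cc(-c3ccc(OCC(O)CO)cc3)oc2c1` differs from compound 3 by hydroxy in place of dimethylamino on a saturated chain carbon, two bonds along the chain from an oxygen on a saturated carbon. Among the compounds with values here, no measured step swaps an amine for a hydroxy, so nothing bears on it directly; the one step shows only that exchanging one amine for another moves this assay modestly.

The expectation for compound 4 is a drop, a number 35 percentage points lower from compound 3 to compound 4 (beyond the scatter), since compound 1 without any amine reads "not active" (no number reported). Compound 4 is thus estimated at 25%, within 5% to 50%.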

Compound 4, a percentage reported as inhibition, at one concentration (the size of the read-out at that concentration, not a potency): 11%
The estimate for compound 4 lay 14 percentage points above the measured number; measured number inside the range.
By their numbers in this assay, from the lowest: compound 4; then compound 2; then compound 3.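

In this assay the step of a number 49 percentage points lower from compound 3 to compound 4 (beyond the scatter) and the step of a number 26 percentage points lower from compound 2 to compound 4 (beyond the scatter) both run the same way, so at this saturated chain carbon each of the two amines reads above hydroxy. The 2,3-dihydroxypropyl chain of compound 4 therefore keeps the hydroxy shared with compound 2 and compound 3, yet falls well short of both amine-bearing chains. Nothing available explains this drop.

As far as these compounds go, whether a morpholine or a primary amine at this carbon would read nearer compound 3 or compound 4 remains open. From the compounds shown here alone, the effect of a longer chain carrying dimethylamino also remains open.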